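Fused-core series: furan-2-yl in place of 4-fluorophenyl

This account rests on a few compounds, and the source may have more. Where it says the series, first, only, none or still open, it means among the compounds named here.

Measured compounds:
Compound 1, `O=C(Nn1c(-c2cccc([N+](=O)[O-])c2)nc2c(-c3ccc(F)cc3)n[nH]c2c1=O)c1cccnc1`: in a functional assay on HT-29 cells (Homo sapiens) for cytotoxicity, read by sulforhodamine B assay, with a stated time of 2 days, tested at 100 uM (on this read-out higher numbers stand for more inhibition at the one concentration tested (going by the name of the read-out) and lower numbers for less inhibition), compound 1 gives 24.7%.
Compound 2, `O=C(Nn1c(-c2cccc([N+](=O)[O-])c2)nc2c(-c3ccco3)n[nH]c2c1=O)c1cccnc1`: in this assay compound 2 gives 11.7%.
Compound 3, `O=C(Nn1c(-c2cccc([N+](=O)[O-])c2)nc2c(-c3ccc(F)cc3)n[nH]c2c1=O)c1ccccc1`: in this assay compound 3 gives 92%.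

Compound 3 stands highest of the three, and its steps to both other compounds lie beyond the scatter. Two single changes are measured. Compound 1 and compound 3 differ by phenyl in place of pyridin-3-yl on a carbonyl carbon, which is also how the two cores of the series differ; this change gives a number 67.3 percentage points higher from compound 1 to compound 3 (beyond the scatter). Compound 1 and compound 2 differ by furan-2-yl in place of 4-fluorophenyl on an aromatic carbon, which gives a number 13 percentage points lower from compound 1 to compound 2 (beyond the scatter).

Compound 4, `O=C(Nn1c(-c2cccc([N+](=O)[O-])c2)nc2c(-c3ccco3)n[nH]c2c1=O)c1ccccc1`, is not yet measured in this assay. It differs from compound 3 by furan-2-yl in place of 4-fluorophenyl on an aromatic carbon. This is the same change as that between compound 1 and compound 2: the group that leaves, the group that enters and the place are described in the same words. The change has been seen only once among the measured compounds, so any expectation rests on a single pair.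

Within the data shown here, for compound 4 the step is expected to be a number 14 percentage points lower from compound 3 to compound 4 (beyond the scatter), taken from the one earlier instance of this change, which gave a number 13 percentage points lower from compound 1 to compound 2 (beyond the scatter). Compound 4 is therefore estimated at 78%, with the expected range running from 55% to 95%.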

Compound 4, a percentage reported as inhibition, at one concentration (the size of the read-out at that concentration, not a potency): 21.2%
The estimate for compound 4 lay 56.8 percentage points above the measured number; the measured number lies below the stated range.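

In this assay, furan-2-yl in place of 4-fluorophenyl gives a number 70.8 percentage points lower from compound 3 to compound 4 (beyond the scatter), and the size of this step does not carry over from one core to the other: the same change on two cores in this assay, a number 13 percentage points lower (beyond the scatter) from compound 1 to compound 2 and a number 70.8 percentage points lower (beyond the scatter) from compound 3 to compound 4, 57.8 percentage points apart, beyond the scatter of two such steps. Phenyl in place of pyridin-3-yl on the carbonyl carbon gives a number 9.5 percentage points higher from compound 2 to compound 4 (within the scatter), so this change does not carry over in size either: the same change on two cores in this assay, a number 67.3 percentage points higher (beyond the scatter) from compound 1 to compound 3 and a number 9.5 percentage points higher (within the scatter) from compound 2 to compound 4, 57.8 percentage points apart, beyond the scatter of two such steps. The two changes are therefore not independent in this set of four compounds, with the high number confined to compound 3, the only one combining phenyl on the carbonyl carbon with 4-fluorophenyl on the aromatic carbon; the furan-2-yl change lowers the number on both cores, but two pairs fix neither a general direction nor a reason for the difference in size.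

As far as these compounds go, it remains open whether the high number of compound 3 needs 4-fluorophenyl itself or would persist with 4-chlorophenyl or an unsubstituted phenyl on the aromatic carbon, and whether a saturated ring such as cyclohexyl would serve in place of phenyl on the carbonyl carbon. From the compounds shown here alone, the 3-nitrophenyl group is common to all four compounds, so the effect of replacing it, for example with 3-aminophenyl, also remains open.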